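This account rests on a few compounds, and the source may have more. Where it says the series, first, only, none or still open, it means among the compounds named here.

Measured compounds:
- compound 1, `CC(C)c1noc(N2CCC(Oc3cc(N4CCc5cc(N6CCCNS6(=O)=O)ccc54)ncn3)CC2)n1`: 24 nM
- compound 2, `CC(C)c1noc(N2CCC(Oc3cc(N4CCc5cc(N6CCCC6=O)ccc54)ncn3)CC2)n1`: 33 nM
- compound 3, `CC(C)c1noc(N2CCC(Oc3cc(N4CCc5cc([S+]([O-])CCO)ccc54)ncn3)CC2)n1`: 48 nM

In an assay on CHO cells for agonist activity at Glucose-dependent insulinotropic receptor (Homo sapiens), read by a luciferase reporter and cAMP accumulation, with a stated time of 2 h (on this read-out higher numbers stand for an effect only at larger amounts of compound and lower numbers for an effect already at smaller amounts), compound 1 gives 24 nM, compound 2 gives 33 nM and compound 3 gives 48 nM. Compound 3 thus sits at the upper end of the three numbers, yet none of the three is separated from another beyond the scatter: a 1.4-fold higher number from compound 1 to compound 2 (0.14 log units; within the scatter), a 2.0-fold higher number from compound 1 to compound 3 (0.30 log units; within the scatter) and a 1.5-fold higher number from compound 2 to compound 3 (0.16 log units; within the scatter). Compound 4, `CC(C)c1noc(N2CCC(Oc3cc(N4CCc5cc(S(=O)(=O)CCO)ccc54)ncn3)CC2)n1`, differs from compound 3 at the same aromatic carbon where the three measured compounds differ from one another: a group of 6 heavy atoms (2 carbon, 3 oxygen, 1 sulfur; no ring) in place of a group of 5 heavy atoms (2 carbon, 2 oxygen, 1 sulfur; no ring), on an aromatic carbon. All three measured steps exchange the group on that carbon, and each of them stayed within the scatter; none of them, however, replaces one sulfur-containing group by the (2-hydroxyethyl)sulfonyl group as this step does, so the comparison is indirect. On that basis the number for compound 4 is expected to stay close to that of compound 3, with no step beyond the scatter, and a 1.1-fold lower number from compound 3 to compound 4 (0.03 log units; within the scatter) is the estimated change in this assay. Compound 4 is therefore estimated at 45 nM, within 18 nM to 110 nM.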

Compound 4, half-maximal effective concentration: 41 nM
Estimate against measurement, compound 4: 1.1-fold (0.04 log units) above, and the stated range covers the measured number.
By their numbers in this assay, from the lowest: compounds 1, 2, 4 and 3 (each within the scatter of the next).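

Going by these compounds alone, measured in this assay, the step of a 1.2-fold lower number from compound 3 to compound 4 (0.07 log units; within the scatter) is the first comparison at this aromatic carbon in which one open-chain sulfur group replaces another, and it leaves the number within the scatter. The (2-hydroxyethyl)sulfonyl group also stays within the scatter of both groups that carry a ring, with a 1.2-fold higher number from compound 2 to compound 4 (0.09 log units; within the scatter) in place of 2-oxopyrrolidin-1-yl and a 1.7-fold higher number from compound 1 to compound 4 (0.23 log units; within the scatter) in place of the six-membered ring group, so the four compounds cannot be told apart by this change at this position. Nothing available explains why these exchanges leave the number within the scatter.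

As far as these compounds go, what a carboxylic acid, a primary amine or a chain longer than 2-hydroxyethyl on the sulfonyl would do at this carbon remains open. Also open, from the compounds shown here alone, is whether the same exchanges would stay within the scatter on a core other than the shared one.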